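This account rests on a few compounds, and the source may have more. Where it says the series, first, only, none or still open, it means among the compounds named here.

Of the compounds shown here, three sharing one core have been tested in a functional assay on MCF7 cells (Homo sapiens) for antiproliferative activity, read by MTT assay, with a stated time of 72 h; a higher number here means a weaker inhibitor, a lower number a stronger inhibitor. Compound 1 `COc1cc(-n2ncnc2-c2ccc(OC(C)C)cc2)cc(OC)c1OC` carries an isopropoxy group on its outer aromatic ring, and in this assay compound 1 gives 610 nM. Compound 2 `COc1cc(-n2ncnc2-c2ccc(F)cc2)cc(OC)c1OC` carries a fluoro group in that position. In this assay compound 2 reaches only the assay limit, > 10000 nM. Compound 3 `COc1cc(-n2ncnc2-c2ccccc2)cc(OC)c1OC` carries a hydrogen there. In this assay compound 3 also reaches only the assay limit, > 10000 nM. Compound 3 therefore stands at the weak end of what this assay can read, sharing (the limit of > 10000 nM in this assay, at which 2 of the 3 values shown sit).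

Compound 4 `COc1cc(-n2ncnc2-c2ccc(OC(F)(F)F)cc2)cc(OC)c1OC` differs from compound 3 by trifluoromethoxy in place of hydrogen on an aromatic carbon. The measured steps that bear on this are an at least 16-fold higher number from compound 1 to compound 3 (1.21 log units; beyond the scatter) and an at least 16-fold higher number from compound 1 to compound 2 (1.21 log units; beyond the scatter), both large, while a step that the two limits leave unreadable from compound 2 to compound 3 cannot be read. Because the loss of the isopropoxy group cost an at least 16-fold higher number from compound 1 to compound 3 (1.21 log units; beyond the scatter), restoring an oxygen-bearing group at the same place in compound 4 is expected to lower the number again, though the trifluoromethoxy group is not the isopropoxy of compound 1. For compound 4 the expected step is an at least 6.6-fold lower number from compound 3 to compound 4 (0.82 log units; beyond the scatter). Compound 4 is thus estimated at 1500 nM, between 400 nM and 10000 nM.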

Compound 4, half-maximal inhibitory concentration: > 10000 nM
Compound 4: no number, only a limit; the forecaster's own chance of this, stated with the estimate: 30%; middle value at least 6.6-fold (0.82 log units) away from the limit.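

Replacing the isopropyl on the oxygen with trifluoromethyl gives an at least 16-fold higher number from compound 1 to compound 4 (1.21 log units; beyond the scatter), so in this assay an oxygen at this position is not enough on its own: what that oxygen carries also counts. Compound 4 gives only a limit of the assay, > 10000 nM. The steps from compound 2 and from compound 3 to compound 4 join two limits and cannot be read, and among the compounds shown only compound 1, with its isopropoxy group, gives a number: the limit of > 10000 nM in this assay, at which 3 of the 4 values shown sit.

The compounds shown leave open whether a methoxy group, a longer butoxy chain or an amine at this place would also give a number. They also leave open how far compound 2, compound 3 and compound 4 actually differ from one another.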